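A few compounds are considered here, and "the series" means these few. Any claim that something is new, unique, unknown or untested is made for them only; others in the source may bear on it.

Compound 1 `CCCN(CCC)c1ccc(/C=C(\C#N)C(=O)O)cc1` and compound 3 `CCCN(CCC)c1ccc(/C=C(\C#N)C(=O)O)c(OC)c1` share a core and differ in one place: methoxy in place of hydrogen on an aromatic carbon. In an assay on RBE4 cells for inhibition of Monocarboxylate transporter 1 (Rattus norvegicus), with a stated time of 15 min (a higher number here means a weaker inhibitor, a lower number a stronger inhibitor), compound 1 gives 10 nM, and compound 3 gives 12 nM; the step of a 1.2-fold higher number from compound 1 to compound 3 (0.08 log units; within the scatter) is within the scatter, so the two read as alike. Compound 2 `CC(C)CN(CC(C)C)c1ccc(/C=C(\C#N)C(=O)O)cc1` is built differently from compound 1, and the difference between the two cores is not broken down here. In this assay compound 2 gives 100 nM, the highest of the three numbers, and its distance from compound 1 and from compound 3 lies beyond the scatter in each case.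

Compound 4 `COc1cc(N(CC(C)C)CC(C)C)ccc1/C=C(\C#N)C(=O)O` has not been measured. It differs from compound 2 as methoxy in place of hydrogen on an aromatic carbon. Within the data shown here, this is the same kind of change as the one from compound 1 to compound 3, though the surroundings differ: in compound 1 the place is meta to a dipropylamino group (7 heavy atoms), in compound 2 meta to a group of 9 heavy atoms. The step of a 1.2-fold higher number from compound 1 to compound 3 (0.08 log units; within the scatter) was within the scatter, and on that rests the expectation that the step of a 1.2-fold higher number from compound 2 to compound 4 (0.08 log units; within the scatter) will be small as well. Compound 4 is therefore expected to give 120 nM in this assay, most likely between 50 nM and 300 nM.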

Compound 4, half-maximal inhibitory concentration: 11 nM
Compound 4: the middle estimate sits 11-fold (1.04 log units) above what was measured, and the stated range ends above it.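

Placing methoxy in place of hydrogen on the aromatic carbon ortho to the 2-carboxy-2-cyanoethenyl group gives a 9.1-fold lower number from compound 2 to compound 4 (0.96 log units; beyond the scatter) in this assay, and a lower number here means a stronger inhibitor. Set beside the earlier step, the same change does not carry over with the same size from one core to the other: the same change on two cores in this assay, a 1.2-fold higher number (0.08 log units; within the scatter) from compound 1 to compound 3 and a 9.1-fold lower number (0.96 log units; beyond the scatter) from compound 2 to compound 4, 11-fold (1.04 log units) apart, beyond the scatter of two such steps This shows that a step within the scatter on one core cannot be assumed to stay small on another, but with only two cores it does not show which difference between them matters, or how the change would behave on any further core.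

The compounds shown leave open whether ethoxy or a hydroxyl group in the same place would follow methoxy on each of the two cores. They also leave open how the step would look with butyl chains on the nitrogen.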